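The source may report more compounds than this note shows. Statements on the series, on what has been measured and on what is new or still open speak of the compounds shown alone.

Measured in a functional assay on HL-60 cells (Homo sapiens) for antiproliferative activity, read by sulforhodamine B assay, with a stated time of 72 h; on this read-out lower numbers stand for stronger inhibition and higher numbers for weaker inhibition:
- compound 1 `Fc1ccccc1NC(=S)N/N=C/c1ccc2ccccc2n1`: > 100000 nM (a limit)
- compound 2 `Cc1cccc(NC(=S)N/N=C/c2ccc3ccccc3n2)c1`: > 100000 nM (a limit)

Compound 2 stands at a limit, > 100000 nM, and has no numerical value. Compound 3 `S=C(NCc1ccccc1)N/N=C/c1ccc2ccccc2n1` carries benzyl in place of 3-methylphenyl on an amide-type nitrogen. Among the measured compounds shown here, the only measured step, a step that the two limits leave unreadable from compound 1 to compound 2, has no readable size, and the other guide is the limit of > 100000 nM in this assay, at which 2 of the 2 values shown sit. On this footing, no step beyond the scatter is expected in this assay, in either direction. The expected step is a number no higher from compound 2 to compound 3 (the limit leaves the size open). Compound 3 is estimated at 100000 nM, with an expected range of 20000 nM to 200000 nM.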

Compound 3, half-maximal inhibitory concentration: 21900 nM
Compound 3: the middle estimate sits 4.6-fold (0.66 log units) above what was measured; measured number inside the range.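

Benzyl on the amide-type nitrogen gives the only number in this assay that is not a limit: the change from 3-methylphenyl gives an at least 4.5-fold lower number from compound 2 to compound 3 (0.65 log units; beyond the scatter), and the change from 2-fluorophenyl gives an at least 4.5-fold lower number from compound 1 to compound 3 (0.65 log units; beyond the scatter). Compounds 2 and 3 have the same atoms, joined differently, so this arrangement alone separates them. The true size of both steps stays open, and the step from compound 1 to compound 2 cannot be read, because the two aryl compounds stand at a limit: the limit of > 100000 nM in this assay, at which 2 of the 3 values shown sit.

Going by these compounds, whether a longer chain such as 2-phenylethyl would extend this change remains open. Also open, on these data alone, is how a cyclohexylmethyl group, without the aromatic ring, would compare with benzyl.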